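Oxan-4-yl in place of cyclobutyl on a carbonyl carbon

A few compounds are considered here, and "the series" means these few. Any claim that something is new, unique, unknown or untested is made for them only; others in the source may bear on it.

- Compound 1 `O=C(C1CCC1)N1N=CCC1c1ccccc1` gives 4.7
- Compound 2 `CC(=O)N1CCC(C(=O)N2N=CC[C@H]2c2ccccc2)CC1` gives 2.5
- Compound 3 `O=C(c1c[nH]nn1)N1CCC(C(=O)N2N=CCC2c2ccccc2)CC1` gives 2

These values come from a physicochemical assay for lipophilicity, read by HPLC, measured as chromatographic lipophilicity, at pH 7.4; on this read-out lower numbers stand for lower lipophilicity and higher numbers for higher lipophilicity. Compound 1 stands highest of the three, with compound 2 and compound 3 lower, beyond the scatter. Compound 4 `O=C(C1CCOCC1)N1N=CCC1c1ccccc1` is not yet measured. It differs from compound 1 in one place: oxan-4-yl in place of cyclobutyl on a carbonyl carbon. Within the data shown here, no measured pair shows this change alone. Among the measured compounds shown here, compound 1, at 4.7, is the only measured compound with no hetero atom in the group on that carbonyl carbon. A drop beyond the scatter in this assay is therefore expected. The expected change is a number 1.30 log units lower from compound 1 to compound 4 (beyond the scatter). For compound 4 the estimated value is 3.4, within an expected range of 2.9 to 3.9.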

Compound 4, distribution coefficient: 3.1
Compound 4: the middle estimate sits 0.30 log units above what was measured; measured number inside the range.
By their numbers in this assay, from the lowest: compound 3; then compound 2; then compound 4; then compound 1.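

In this assay, oxan-4-yl in place of cyclobutyl on a carbonyl carbon gives a number 1.60 log units lower from compound 1 to compound 4 (beyond the scatter) as a clean one-place comparison. This is the only pair shown in which the group on that carbon changes alone, so the size of this change at this position can now be read directly. Nothing measured here accounts for the size of the step.

The compounds shown leave open whether the step follows the ring oxygen or the larger ring. Cyclohexyl on the same carbonyl carbon would separate the two, and a methoxymethyl chain would test whether a ring is needed at all.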